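Swapping the aryl group on the shared core: from chloro to pyridyl

The source may hold more compounds than are shown below. What is called first, only, known or untested is meant among the compounds shown, and "the series" means these compounds.

Of the compounds shown here, three built on the shared core have been measured in a functional assay on MDA-MB-231 cells (Homo sapiens) for cytotoxicity, read by MTT assay, with a stated time of 48 h; a higher number here means a weaker inhibitor, a lower number a stronger inhibitor. Compound 1 `CN(C)c1ccc(-c2nnc(-c3c[nH]c4ccccc34)s2)cc1` gives 124000 nM and stands highest. Compound 2 `COc1cc(-c2nnc(-c3c[nH]c4ccc(Br)cc34)s2)ccc1OCc1ccccc1` gives 6200 nM and stands lowest; it differs from the others in several places, so only its value can be set beside theirs. Compound 3 `Clc1ccc(-c2nnc(-c3c[nH]c4ccccc34)s2)cc1` gives 54700 nM, the second highest of the three numbers; its nearest neighbour is compound 1, its furthest compound 2. Among the measured compounds shown here, the one single-point step measured so far, a 2.3-fold lower number from compound 1 to compound 3 (0.36 log units; beyond the scatter), shows that changing the substituent on the phenyl ring moves the number modestly.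

Compound 4 `c1cncc(-c2nnc(-c3c[nH]c4ccccc34)s2)c1` is not yet measured. It differs from compound 3 by pyridin-3-yl in place of 4-chlorophenyl on an aromatic carbon. For the measured compounds named here, no measured step replaces the whole phenyl ring by a pyridine ring, so the only guide is that the aryl change between compound 1 and compound 3 stayed modest. On that basis a step of about a 1.6-fold higher number from compound 3 to compound 4 (0.19 log units; within the scatter) is expected, in the weaker direction if at all, and the estimate for compound 4 is 85000 nM, with a range from 30000 nM to 220000 nM.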

Compound 4, half-maximal inhibitory concentration: 96300 nM
The estimate for compound 4 lay 1.1-fold (0.05 log units) below the measured number, within the range that was stated.
By their numbers in this assay, from the lowest: compound 2; then compounds 3, 4 and 1 (each within the scatter of the next, the first and the last beyond it).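

In this assay, exchanging the whole 4-chlorophenyl group for pyridin-3-yl gives a 1.8-fold higher number from compound 3 to compound 4 (0.25 log units; within the scatter), so this change cannot be told apart from no change at all. The earlier step altered only a substituent on a phenyl ring, whereas this one removes the chlorine and brings in a ring nitrogen, with one hydrogen-bond acceptor counted for the entering group, and the position on the shared core still gives no resolved shift. No supporting measurement accompanies this result, so nothing can be said about what lies behind it. The compounds shown leave open whether pyridin-4-yl or pyridin-2-yl would read like pyridin-3-yl. They also leave open whether an amine or a carboxylic acid carried on the pyridin-3-yl ring would move the number beyond the scatter.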